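The source may report more compounds than this note shows. Statements on the series, on what has been measured and on what is new or still open speak of the compounds shown alone.

Measured compounds:
compound 1 `CCNC(=O)c1noc(-c2cc(C(C)C)c(O)cc2O)c1-c1cc(COCC(=O)OC)no1` — in a functional assay on A2780 cells (Homo sapiens) for inhibition (on this read-out lower numbers stand for stronger inhibition and higher numbers for weaker inhibition), compound 1 gives "not determined" (no result reported)
compound 2 `C=CNCc1cc(-c2c(C(=O)NCC)noc2-c2cc(C(C)C)c(O)cc2O)on1` — in this assay compound 2 gives 43 nM
compound 3 `CCNC(=O)c1noc(-c2cc(C(C)C)c(O)cc2O)c1-c1cc(CN2CCCCC2)no1` — in this assay compound 3 gives 62 nM

Compound 1 stands on no number here; the shared core is seen only through compounds 2 and 3. Compound 4 `CCNC(=O)c1noc(-c2cc(C(C)C)c(O)cc2O)c1-c1cc(C(=O)O)no1` differs from compound 1 by carboxy in place of ((methoxycarbonyl)methoxy)methyl on an aromatic carbon. Among the compounds with values here, the only measured step, a 1.4-fold higher number from compound 2 to compound 3 (0.16 log units; within the scatter), changes a group on a saturated chain carbon, not on the aromatic carbon altered here, so no step bears directly on the change from compound 1 to compound 4. The expectation therefore rests only on the band set by compounds 2 and 3 and is wide. For compound 4 the estimate in this assay is 300 nM, expected to fall between 60 nM and 1500 nM.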

Compound 4, half-maximal inhibitory concentration: 20000 nM
Estimate against measurement, compound 4: 67-fold (1.82 log units) below; the measured number lies above the stated range.
By their numbers in this assay, from the lowest: compounds 2 and 3 (each within the scatter of the next); then compound 4.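

In this assay, this aromatic carbon of the five-membered ring responds strongly to what it carries: carboxy in place of (piperidin-1-yl)methyl gives a 320-fold higher number from compound 3 to compound 4 (2.51 log units; beyond the scatter), and carboxy in place of (vinylamino)methyl gives a 470-fold higher number from compound 2 to compound 4 (2.67 log units; beyond the scatter). The two amine-bearing chains in compound 2 and compound 3 stay within the scatter of each other, so the large steps appear only with carboxy. Nothing in hand accounts for the size of these steps.

Compound 1 has no number, so the change from compound 1 to compound 4 cannot be read. On these data alone, whether a methyl ester at this carbon, or a carboxylic acid on a longer chain, gives numbers nearer those of the amines remains open.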